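The source may hold more compounds than are shown below. What is called first, only, known or untested is meant among the compounds shown, and "the series" means these compounds.

In a functional assay on HCT-116 cells (Homo sapiens) for inhibition, read by MTT assay, with a stated time of 48 h (on this read-out higher numbers stand for weaker inhibition and lower numbers for stronger inhibition), compound 1 `C/C=C/C(=O)N(Cc1cc(OC)c(OC)c(OC)c1)c1ccc(OC)c(O)c1` gives 8450 nM, compound 2 `C/C=C/C(=O)N(Cc1ccc(OC)c(OC)c1)c1cc(OC)c(OC)c(OC)c1` gives 32800 nM and compound 3 `COc1ccc(N(Cc2cc(OC)c(OC)c(OC)c2)C(=O)CCl)cc1O` gives 22500 nM. Compound 3 therefore lies within the usual scatter of compound 2 and is clearly weaker than compound 1. Compound 4 `COc1ccc(N(Cc2cc(OC)c(OC)c(OC)c2)C(=O)CN=[N+]=[N-])cc1O` differs from compound 3 by azido in place of chloro on a saturated chain carbon bound to a carbonyl carbon. Among the compounds with values here, only one measured step touches this part of the molecule: a 2.7-fold higher number from compound 1 to compound 3 (0.43 log units; beyond the scatter), a modest change. Within the data shown here, no measured compound carries azido. A step of that size or smaller is thus expected in this assay, with no firm direction and probably nothing beyond the scatter. The expected change is a 1.2-fold higher number from compound 3 to compound 4 (0.08 log units; within the scatter). For compound 4 the estimated value is 27000 nM, with an expected range from 11000 nM to 65000 nM.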

Compound 4, half-maximal inhibitory concentration: 38800 nM
For compound 4 the middle estimate is 1.4-fold (0.16 log units) below the measured one; the measured number falls inside the stated range.
By their numbers in this assay, from the lowest: compound 1; then compounds 3, 2 and 4 (each within the scatter of the next).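

In this assay, azido in place of chloro on a saturated chain carbon bound to a carbonyl carbon gives a 1.7-fold higher number from compound 3 to compound 4 (0.24 log units; within the scatter), so these two groups cannot be told apart here. Replacing prop-1-en-1-yl with azidomethyl gives a 4.6-fold higher number from compound 1 to compound 4 (0.66 log units; beyond the scatter), so a second replacement, after chloromethyl, also reads weaker than compound 1. Nothing available here accounts for these steps. As far as these compounds go, how an amine or a carboxylic acid on that saturated chain carbon would read remains open, as does whether any group on the carbonyl carbon can match prop-1-en-1-yl.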